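Adding a cyano group to compound 3

This account rests on a few compounds, and the source may have more. Where it says the series, first, only, none or still open, it means among the compounds named here.

In a functional assay on MC-38 cells (Mus musculus) for antiproliferative activity (a higher number here means a weaker inhibitor, a lower number a stronger inhibitor), three compounds sharing one core have been measured. Compound 1 (`Cc1ccc(S(=O)(=O)Nc2cccc3cc[nH]c23)cc1`) gives 2.4 ug/mL, compound 2 (`O=S(=O)(Nc1cccc2cc[nH]c12)c1ccc(Cl)cc1`) gives 7 ug/mL, and compound 3 (`Nc1ccc(S(=O)(=O)Nc2cccc3cc[nH]c23)cc1`) gives 6.1 ug/mL. Compound 3 therefore sits level with compound 2, with a 1.1-fold lower number from compound 2 to compound 3 (0.06 log units; within the scatter), while the number for compound 1 is clearly lower, with a 2.5-fold higher number from compound 1 to compound 3 (0.41 log units; beyond the scatter).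

Compound 4 (`N#Cc1c[nH]c2c(NS(=O)(=O)c3ccc(N)cc3)cccc12`) has cyano in place of hydrogen on an aromatic carbon of a five-membered aromatic ring with 1 nitrogen, two ring bonds from the ring nitrogen: cyano in place of hydrogen on an aromatic carbon. Among the compounds with values here, no measured step touches that carbon, so there is no direct guide. The closest evidence is the swaps of one group for another on a different aromatic carbon, such as a 2.9-fold higher number from compound 1 to compound 2 (0.46 log units; beyond the scatter), and these were modest. A similarly modest step is expected in this assay, with a tentative lean towards a lower number that the data cannot settle. The expected change is a 2.0-fold lower number from compound 3 to compound 4 (0.31 log units; beyond the scatter). Compound 4 is estimated at 3 ug/mL, with an expected range from 0.7 ug/mL to 10 ug/mL.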

Compound 4, half-maximal inhibitory concentration: 0.28 ug/mL
The estimate for compound 4 lay 11-fold (1.03 log units) above the measured number; the measured number lies below the stated range.
By their numbers in this assay, from the lowest: compound 4; then compound 1; then compounds 3 and 2 (each within the scatter of the next).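

In this assay, a cyano group in place of hydrogen on the aromatic carbon two ring bonds from the ring nitrogen gives a 22-fold lower number from compound 3 to compound 4 (1.34 log units; beyond the scatter), a much larger step than the earlier swaps on a different aromatic carbon, which were modest or within the scatter. Within the data shown here, this carbon, untouched by the earlier compounds, is therefore a place where adding just one small group can change the number far more than those swaps did. Nothing available here explains why the cyano group has this effect.

The compounds shown leave open whether a different group on this carbon, such as a carboxylic acid or an amide, would give a similar step. Going by these compounds, it also remains open whether cyano would give the same step with the methyl of compound 1 or the chloro of compound 2 in place of the amino group.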